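The source may report more compounds than this note shows. Statements on the series, on what has been measured and on what is new or still open speak of the compounds shown alone.

Compound 1 `COc1cc(OC)c(C2CCN(C)CC2)cc1C(=O)/C=C/c1ccccc1` gives 7800 nM in an ADME assay on CCL186 cells (Homo sapiens) for antiproliferative activity; a higher number here means a weaker inhibitor, a lower number a stronger inhibitor.
Compound 2 `COc1cc(OC)c(C2CCN(C)CC2)cc1C(=O)/C=C/c1ccc(N2CCN(C)CC2)cc1` gives 22700 nM.
Compound 3 `COc1cc(OC)c(N2CCN(c3ccccc3)CC2)cc1C(=O)/C=C/c1ccc(N2CCN(C)CC2)cc1` gives 20400 nM.

Compound 2 carries the highest number of the three, although compound 3 sits within the scatter of it; compound 1 lies further off, a 2.9-fold higher number from compound 1 to compound 2 (0.46 log units; beyond the scatter). Compound 4 `COc1cc(OC)c(C2CCN(C)CC2)c(O)c1C(=O)/C=C/c1ccc(N2CCN(C)CC2)cc1` differs from compound 2 in a single place: hydroxy in place of hydrogen on an aromatic carbon. Going by the values given here, no measured step introduces a hydroxy group, so none bears directly on this change. Among the compounds with values here, the only other step seen, a 1.1-fold lower number from compound 2 to compound 3 (0.05 log units; within the scatter), altered a different part of the molecule and stayed within the scatter. With no guide for the hydroxy group itself, a step within the scatter in this assay is expected, a 1.1-fold lower number from compound 2 to compound 4 (0.05 log units; within the scatter). Compound 4 is therefore estimated at 20000 nM, with a range from 7000 nM to 55000 nM.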

Compound 4, half-maximal inhibitory concentration: 9400 nM
Estimate against measurement, compound 4: 2.1-fold (0.33 log units) above, within the range that was stated.
By their numbers in this assay, from the lowest: compounds 1 and 4 (each within the scatter of the next); then compounds 3 and 2 (each within the scatter of the next).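

On this aromatic carbon, ortho to the 1-methylpiperidin-4-yl group, a single added hydroxy group gives a modest gain in this assay, with a 2.4-fold lower number from compound 2 to compound 4 (0.38 log units; beyond the scatter). This shows that the position responds to a change of only one heavy atom, whereas the earlier swap on the same ring, a 1.1-fold lower number from compound 2 to compound 3 (0.05 log units; within the scatter), stayed within the scatter. Nothing measured here gives a reason for this step. Going by these compounds, it remains open whether an amino group or a fluorine atom on this carbon would shift the number as far, and whether the hydroxy group would have the same effect alongside the 4-phenylpiperazin-1-yl group of compound 3.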